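Two Aryl Amide Swaps at the Same Carbonyl Carbon

The source may report more compounds than this note shows. Statements on the series, on what has been measured and on what is new or still open speak of the compounds shown alone.

Compound 2 `O=C(NC[C@@H]1C[C@@H]2C=C[C@@H]1C2)NS(=O)(=O)N1CCC(CCNC(=O)c2cccc3c2OCCO3)CC1` was tested in a functional assay on the whole organism (blood) with Rattus norvegicus as the target, with stated times of 24 h and 1 h, at a dose of 5 mg/kg by the intraperitoneal route (a lower number here means a weaker effect, a higher number a stronger effect of the compound at the dose given), and gives 11%. Its nearest measured neighbour is compound 1 `COc1ccc(C(=O)NCCC2CCN(S(=O)(=O)NC(=O)NC[C@@H]3C[C@@H]4C=C[C@@H]3C4)CC2)cn1`, which in this assay gives 11%; the two stand level at the digits shown, and the step of no change at the digits printed from compound 1 to compound 2 (within the scatter) lies within the scatter, so compound 2 stands on the same footing as compound 1 with no difference of order between them.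

Compound 3 `Cn1cc(C(=O)NCCC2CCN(S(=O)(=O)NC(=O)NC[C@@H]3C[C@@H]4C=C[C@@H]3C4)CC2)c(=O)n(C)c1=O` has not yet been measured in this assay. It differs from compound 2 only at the amide end: a group of 10 heavy atoms (6 carbon, 2 nitrogen, 2 oxygen; one six-membered aromatic ring with 2 hetero atoms) in place of a group of 10 heavy atoms (8 carbon, 2 oxygen; one six-membered non-aromatic ring with 2 hetero atoms, one six-membered aromatic ring of carbon only), on a carbonyl carbon

Among the measured compounds shown here, the one measured step that bears on this change is the exchange of one aryl group for another on the same carbonyl carbon, from compound 1 to compound 2, which moved the read-out by nothing beyond the scatter. On that basis the expected step of no change at the digits printed from compound 2 to compound 3 (within the scatter) is likewise none beyond the scatter. Compound 3 is therefore estimated to give about 11% in this assay, with a range from 0% to 25%.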

Compound 3, a percentage reported as activity, at one dose (the size of the read-out at that dose, not a potency): 23%
Compound 3: middle estimate off by 12 percentage points, on the low side, and the stated range covers the measured number.
By their numbers in this assay, from the lowest: compounds 1 and 2 (each within the scatter of the next); then compound 3.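

This result shows that the group on the carbonyl carbon, whose other neighbour is an amide-type nitrogen, is not a place where every exchange passes without effect in this assay: the entering group, with its six-membered aromatic ring with 2 hetero atoms and its 2 double bonds outside aromatic rings, gives a number 12 percentage points higher from compound 2 to compound 3 (beyond the scatter) and a number 12 percentage points higher from compound 1 to compound 3 (beyond the scatter). The earlier swap of 6-methoxypyridin-3-yl for 2,3-dihydro-1,4-benzodioxin-5-yl had shown only two groups that read level, so this is the first sign that the read-out can respond to a change here. Between compound 2 and compound 3 the count of heavy atoms stays the same while the atom types, the rings and the hydrogen-bond acceptors differ, and nothing available explains the rise.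

The compounds shown leave open which of those differences goes with the higher number, and whether a plain phenyl group or a carboxylic acid on the same carbonyl carbon would read with compound 1 and compound 2 or with compound 3. They also leave open whether the step holds at other doses, since the read-out comes from one dose only.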